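The source may report more compounds than this note shows. Statements on the series, on what has been measured and on what is new or still open speak of the compounds shown alone.

Measured compounds:
- compound 1, `COc1ccc(-c2ccccn2)c2cc(C(=O)Nc3ccncc3)oc12` — "not determined" (no result reported) in a functional assay on the whole organism for inhibition, with Mus musculus as the target, at a dose of 10 mg/kg by the oral route; a higher number here means more inhibition at the dose given (going by the name of the read-out), a lower number less inhibition
- compound 2, `COc1ccc(-c2cccnc2)c2cc(C(=O)Nc3ccncc3)oc12` — 38% in this assay

Among the compounds with values here, compound 2 is the only compound of the set with a number in this assay; compound 1 carries no result there, so no step between measured compounds can be drawn and nothing is known about how a change of the pyridyl ring on the shared core moves the read-out.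

Compound 3, `COc1ccc(-c2ccncc2)c2cc(C(=O)Nc3ccncc3)oc12`, is the next entry. It differs from compound 2 as follows: pyridin-4-yl in place of pyridin-3-yl on an aromatic carbon. Within the data shown here, with no comparable step in hand, the expectation for this change is a step in this assay of no more than the scatter, with no direction to favour, and the estimate leans on the value of compound 2 alone. Compound 3 is therefore expected to give about 36%, within 12% to 60%, which means an expected step of a number 2 percentage points lower from compound 2 to compound 3 (within the scatter) from the measured compound.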

Compound 3, a percentage reported as inhibition, in the whole organism at one dose (the size of the read-out at that dose, not a potency): 48%
The estimate for compound 3 lay 12 percentage points below the measured number, within the range that was stated.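

In this assay, within the data shown here, the step of a number 10 percentage points higher from compound 2 to compound 3 (within the scatter) is the first readable change at this position, with pyridin-4-yl in place of pyridin-3-yl on the aromatic carbon para to the methoxy group. Within this pair, the read-out does not separate the two pyridyl groups, and the same heavy-atom and acceptor counts on both sides leave only the way the ring is joined as the difference. No supporting measurement accompanies this step to account for the result.

Steps involving compound 1 cannot be read, so the pyridyl ring of that compound remains unplaced relative to the other two. Also open, on these data alone, is whether a ring nitrogen is needed here at all: a plain phenyl ring, or a phenyl ring carrying an amine or a carboxylic acid, would test this at the same position.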